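Series notes: changing the carbonyl aryl group of compound 2

The source may hold more compounds than are shown below. What is called first, only, known or untested is meant among the compounds shown, and "the series" means these compounds.

Measured in a functional assay on HL-60 cells (Homo sapiens) for antiproliferative activity, with a stated time of 24 h; on this read-out higher numbers stand for weaker inhibition and lower numbers for stronger inhibition:
- Compound 1 `NC(=O)c1c(NC(=O)c2ccc(C(F)(F)F)cc2)sc2c1CCN(Cc1ccc(Cl)cc1)C2`: > 50000 nM
- Compound 2 `NC(=O)c1c(NC(=O)c2ccc(C(F)(F)F)cc2)sc2c1CCN(Cc1c(Cl)cccc1Cl)C2`: 10600 nM

Compound 1 gives > 50000 nM, which is a limit of the assay and not a number. Within the data shown here, compound 2 has the only numerical value so far, 10600 nM.

The next compound to be measured is compound 3 `NC(=O)c1c(NC(=O)c2ccccc2F)sc2c1CCN(Cc1c(Cl)cccc1Cl)C2`. It keeps the 2,6-dichlorophenyl group of compound 2 and changes the group on the carbonyl carbon: 2-fluorophenyl in place of 4-(trifluoromethyl)phenyl on a carbonyl carbon.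

Among the measured compounds shown here, the only measured step is an at least 4.7-fold lower number from compound 1 to compound 2 (0.67 log units; beyond the scatter). That step exchanges 4-chlorophenyl for 2,6-dichlorophenyl, and compound 3 leaves this part unchanged. For the measured compounds named here, it therefore gives no direct size for the new change, and no measured step covers the group on the carbonyl carbon. Going by the values given here, with no such step to go on, no shift beyond the scatter is expected, and the uncertainty is wide. A result at the limit seen for compound 1 remains possible.

The expected change is a 1.4-fold higher number from compound 2 to compound 3 (0.15 log units; within the scatter).

For compound 3 the estimate in this assay is 15000 nM, with an expected range of 5000 nM to 45000 nM.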

Compound 3, half-maximal inhibitory concentration: 10300 nM
Beside the measured number, compound 3's estimate is 1.5-fold (0.16 log units) above it; measured number inside the range.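

The group on the carbonyl carbon now has its first measured step in this assay: with 2-fluorophenyl in place of 4-(trifluoromethyl)phenyl, the read-out shows a 1.0-fold lower number from compound 2 to compound 3 (0.01 log units; within the scatter). Among these compounds, the entering group has fewer heavy atoms than the leaving group, so on the 2,6-dichlorophenyl background this exchange of groups on the carbonyl carbon leaves the read-out unmoved, whereas the only earlier step concerned the other end of the molecule. Compound 2 and compound 3 both give numbers, and the one value at the limit of the assay remains that of compound 1, which carries the 4-chlorophenyl group: the limit of > 50000 nM in this assay, at which 1 of the 3 values shown sits.

Among the compounds shown here, whether this exchange would read the same with the 4-chlorophenyl group of compound 1 stays open, and only two aryl groups are covered on the carbonyl carbon. An amine, a carboxylic acid or a longer saturated chain on that phenyl ring, or a pyridine ring in its place, would show whether this position responds to anything more than these two fluorine-bearing phenyl groups.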